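Swapping an anilino group for a methylpiperidine on the pyridine

A few compounds are considered here, and "the series" means these few. Any claim that something is new, unique, unknown or untested is made for them only; others in the source may bear on it.

Of the compounds shown here, three sharing one core have been measured in a functional assay on CHO-K1 cells for antagonist activity at transient receptor potential cation channel subfamily V member 1 (Homo sapiens), read by FLIPR; a higher number here means a weaker inhibitor, a lower number a stronger inhibitor. Compound 1 `CC(C(=O)NCc1ccc(C(F)(F)F)nc1NCC1CCN(C(=O)OC(C)(C)C)CC1)c1ccc(NS(C)(=O)=O)c(F)c1` gives 19.3 nM. Compound 2 `Cc1ccc(Nc2nc(C(F)(F)F)ccc2CNC(=O)C(C)c2ccc(NS(C)(=O)=O)c(F)c2)cc1C` gives 39.3 nM, the second highest of the three numbers; compound 1 sits at a lower number, beyond the scatter, while compound 3 `C[C@H](C(=O)NCc1ccc(C(F)(F)F)nc1N1CC[C@@H](N(C)C)C1)c1ccc(NS(C)(=O)=O)c(F)c1` gives 101 nM, a higher number than compound 2, also beyond the scatter. Compound 2 therefore stands between the other two.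

The unmeasured compound 4 `CC(C(=O)NCc1ccc(C(F)(F)F)nc1N1CCCCC1C)c1ccc(NS(C)(=O)=O)c(F)c1` differs from compound 2 in one place: 2-methylpiperidin-1-yl in place of (3,4-dimethylphenyl)amino on an aromatic carbon. Among the measured compounds shown here, no step between two measured compounds isolates this change, so its effect cannot be read from a precedent. Compound 1 and compound 3, which carry saturated nitrogen rings in the same region, bracket compound 2 on either side, which suggests the new ring is unlikely to move the number far. Compound 4 is expected to land near compound 2, with the step of a 1.4-fold higher number from compound 2 to compound 4 (0.15 log units; within the scatter) estimated as small, not clearly beyond the scatter, in either direction. The estimated value for compound 4 is 55 nM, within a range from 18 nM to 170 nM.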

Compound 4, inhibition constant: 2.9 nM
For compound 4 the middle estimate is 19-fold (1.28 log units) above the measured one; measured number below the stated range.
By their numbers in this assay, from the lowest: compound 4; then compound 1; then compound 2; then compound 3.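

Placing 2-methylpiperidin-1-yl in place of (3,4-dimethylphenyl)amino, on the aromatic carbon next to the ring nitrogen, gives in this assay a 14-fold lower number from compound 2 to compound 4 (1.13 log units; beyond the scatter) and so makes this a large step. A group with no aromatic ring, no hydrogen-bond donor and fewer heavy atoms is therefore not just accepted at this position but gives a far lower number than the group it replaces. Nothing available explains why the number falls so far.

The step changes the ring, the donor and the methyl together, so the compounds shown leave open which of these differences accounts for it. From the compounds shown here alone, it also remains open whether a piperidin-1-yl without the methyl, or a morpholine on the same carbon, would keep the number this low.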